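The source may hold more compounds than are shown below. What is called first, only, known or untested is meant among the compounds shown, and "the series" means these compounds.

Measured compounds:
- compound 1, `O=C(O)CCC/C=C1/C[C@H]2CC[C@H](/C=N/NC(=O)Nc3ccc(Cl)c(Cl)c3)[C@H]2C1`: 1800 nM
- compound 2, `O=C(O)CCC/C=C1\C[C@H]2CC[C@H](/C=N/NC(=O)Nc3ccc(Cl)c(Cl)c3)[C@H]2C1`: 9000 nM
- compound 3, `O=C(O)CCC/C=C1\C[C@H]2C[C@@H](O)[C@H](/C=N/NC(=O)Nc3ccccc3)[C@H]2C1`: 1700 nM

In a functional assay on a cell-free system (plasma) for agonist activity at thromboxane A2 receptor (Homo sapiens) (on this read-out higher numbers stand for weaker inhibition and lower numbers for stronger inhibition), compound 2 gives the highest of the three numbers: compound 1 sits lower, and compound 3 sits lower still. Going by the values given here, the only step that can be counted between measured compounds, a 5.0-fold higher number from compound 1 to compound 2 (0.70 log units; beyond the scatter), rests on (the fact that compounds 1 and 2 differ only in the configuration as drawn), a change of configuration at a double bond, and says nothing about the aryl group on the amide-type nitrogen.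

Compound 4, `O=C(O)CCC/C=C1\C[C@H]2CC[C@H](/C=N/NC(=O)Nc3ccc([N+](=O)[O-])cc3)[C@H]2C1`, is compound 2 with 4-nitrophenyl in place of 3,4-dichlorophenyl on an amide-type nitrogen. Among the compounds with values here, no measured pair isolates such an aryl exchange; compound 3 carries an unsubstituted phenyl but also differs from compound 2 in the ring, so its value can only be noted beside that of compound 2, not read as a step. Within the data shown here, with no comparable step in hand, the number for compound 4 in this assay is expected to stay close to that of compound 2, the step of a 1.1-fold lower number from compound 2 to compound 4 (0.05 log units; within the scatter) being expected to fall within the scatter. Compound 4 is therefore estimated at 8000 nM, within 2500 nM to 30000 nM.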

Compound 4, half-maximal inhibitory concentration: 1700 nM
Compound 4: the middle estimate sits 4.7-fold (0.67 log units) above what was measured, and the stated range ends above it.
By their numbers in this assay, from the lowest: compounds 3, 4 and 1 (each within the scatter of the next); then compound 2.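

In this assay, the aryl group on the amide-type nitrogen proves able to move the number by more than the scatter: with 4-nitrophenyl in place of 3,4-dichlorophenyl, the result is a 5.3-fold lower number from compound 2 to compound 4 (0.72 log units; beyond the scatter). Going by these compounds alone, the earlier counted step, a 5.0-fold higher number from compound 1 to compound 2 (0.70 log units; beyond the scatter), concerned only the configuration at a double bond, so this is the first step that isolates a change at this position. The available evidence does not bear on this aryl exchange.

On these data alone, the step rests on one pair with the double bond as drawn in compound 2, so whether it also holds with the configuration of compound 1 remains open. Nor does one pair separate losing the chlorines from gaining the nitro group; 4-chlorophenyl or 4-aminophenyl at this position on the same core would speak to that.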